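The compounds below may be only part of what the source reports. "The series", "measured", "known", "first", "only" and "open" are said of these compounds alone.

Measured so far in a functional assay on HeLa cells (Homo sapiens) for antiproliferative activity, read by MTT assay, with a stated time of 48 h; on this read-out lower numbers stand for stronger inhibition and higher numbers for weaker inhibition:
- compound 1 `COc1ccc(-c2cc3c(cn2)[nH]c(=O)n3-c2cc(OC)c(OC)c(OC)c2)cc1` gives 1210 nM
- compound 2 `COc1ccc(-c2cc3c(cn2)[nH]c(=O)n3-c2cc(OC)c(OC)c(OC)c2)cc1O` gives 490 nM
- compound 3 `COc1ccc(-c2cc3c(cn2)[nH]c(=O)n3-c2cc(OC)c(OC)c(OC)c2)cc1C` gives 1410 nM

Compound 1 sits at the upper end of these numbers, level with compound 3 as a 1.2-fold higher number from compound 1 to compound 3 (0.07 log units; within the scatter) shows, while a 2.5-fold lower number from compound 1 to compound 2 (0.39 log units; beyond the scatter) marks the one clear gap from it.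

Compound 4 `COc1ccc(-c2cc3c(cn2)[nH]c(=O)n3-c2cc(OC)c(OC)c(OC)c2)cc1N` differs from compound 1 by one change, (amino in place of hydrogen on an aromatic carbon), amino in place of hydrogen on an aromatic carbon, ortho to a methoxy group. The hydroxy of compound 2 and the methyl of compound 3 stand in that same place, so both steps bear on it, and they disagree. Among the compounds with values here, no amino compound has been measured, so the choice between them is a judgement. A modest drop like the hydroxy step is expected, with no change still possible. The expected step is a 2.4-fold lower number from compound 1 to compound 4 (0.38 log units; beyond the scatter), on the estimate below. Compound 4 is estimated at 500 nM, with an expected range of 130 nM to 1500 nM in this series.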

Compound 4, half-maximal inhibitory concentration: 770 nM
The estimate for compound 4 lay 1.5-fold (0.19 log units) below the measured number; measured number inside the range.
By their numbers in this assay, from the lowest: compounds 2, 4, 1 and 3 (each within the scatter of the next, the first and the last beyond it).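

In this assay, amino on this aromatic carbon, ortho to a methoxy group, cannot be told apart from any of the three groups compared: a 1.6-fold lower number from compound 1 to compound 4 (0.20 log units; within the scatter), a 1.8-fold lower number from compound 3 to compound 4 (0.26 log units; within the scatter) and a 1.6-fold higher number from compound 2 to compound 4 (0.20 log units; within the scatter). Compound 2 and compound 3 remain separated at this place, yet compound 4 does not side clearly with either. No measurement offers an explanation for these differences.

Still open, as far as these compounds go, is whether an acetamide or a methylamino group here would separate from compound 1. Also open, from the compounds shown here alone, is whether a hydroxymethyl group would match the hydroxy of compound 2.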